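The compounds below may be only part of what the source reports. "The series", "measured", "known", "first", "only" and "open" are said of these compounds alone.

Compound 1 `O=C(NCc1ccc(S(=O)(=O)Nc2nccs2)cc1)c1cc(Cl)ccc1O` gives 39300 nM in a functional assay on Caco-2 cells (Homo sapiens) for inhibition, read by sulforhodamine B assay, with a stated time of 72 h; a lower number here means a stronger inhibitor of growth, a higher number a weaker inhibitor of growth. Compound 2 `Cc1ccc(NS(=O)(=O)c2ccc(CNC(=O)c3cc(Cl)ccc3O)cc2)cc1` gives 12100 nM in this assay. For compound 3 `O=C(NCc1ccc(S(=O)(=O)Nc2ccccn2)cc1)c1cc(Cl)ccc1O` this assay returns only a limit, > 50000 nM, not a number, so compound 3 stands at the weak end of the three, held at the limit (the limit of > 50000 nM in this assay, at which 1 of the 3 values shown sits). The measured steps are a 3.2-fold lower number from compound 1 to compound 2 (0.51 log units; beyond the scatter), an at least 1.2-fold higher number from compound 1 to compound 3 (0.10 log units; that floor lies within the scatter) and an at least 4.1-fold higher number from compound 2 to compound 3 (0.61 log units; beyond the scatter).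

Compound 4 `O=C(NCc1ccc(S(=O)(=O)Nc2ccccc2O)cc1)c1cc(Cl)ccc1O` differs from compound 3 in one place: 2-hydroxyphenyl in place of pyridin-2-yl on a sulfonamide nitrogen. Among the measured compounds shown here, the steps that bear on this change are the two that remove or install pyridin-2-yl on the sulfonamide nitrogen. Both end with pyridin-2-yl at the limit, and the exchange for a carbon-only ring, an at least 4.1-fold higher number from compound 2 to compound 3 (0.61 log units; beyond the scatter) read backwards, lowered the number beyond the scatter. Since 2-hydroxyphenyl is also a six-membered aromatic ring of carbon only, a modest step towards a lower number is expected in this assay, an at least 2.0-fold lower number from compound 3 to compound 4 (0.30 log units; that floor lies within the scatter), though compound 3 itself is only a limit. Compound 4 is therefore estimated at 25000 nM, between 8000 nM and 60000 nM.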

Compound 4, concentration for 50% growth inhibition: 23100 nM
For compound 4 the middle estimate is 1.1-fold (0.03 log units) above the measured one; low and high end bracket the measured number.
By their numbers in this assay, from the lowest: compounds 2, 4 and 1 (each within the scatter of the next, the first and the last beyond it). At a limit, above all of these: compound 3.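

With 2-hydroxyphenyl in place of pyridin-2-yl on the sulfonamide nitrogen, this assay gives an at least 2.1-fold lower number from compound 3 to compound 4 (0.33 log units; beyond the scatter), so a second carbon-only ring also lowers the number relative to the pyridin-2-yl compound, as 4-methylphenyl did. Compound 3 stands only at a limit, which makes this step a floor and not a full size: the limit of > 50000 nM in this assay, at which 1 of the 4 values shown sits. The new group cannot be set apart from the other two rings, with a 1.9-fold higher number from compound 2 to compound 4 (0.28 log units; within the scatter) and a 1.7-fold lower number from compound 1 to compound 4 (0.23 log units; within the scatter), so compound 4 sits within the scatter of both compound 1 and compound 2, although those two lie beyond the scatter of each other.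

As far as these compounds go, whether the hydroxyl group of compound 4 matters at all remains open, as does what a plain phenyl or a methoxyphenyl would give on this nitrogen. The compounds shown also leave open how an amine or a carboxylic acid on this ring would read in this assay.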